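The source may hold more compounds than are shown below. What is called first, only, known or untested is meant among the compounds shown, and "the series" means these compounds.

Measured so far in an assay for inhibition of cytochrome P450 1A1 (Homo sapiens), read by fluorescence, using microsomes, with a stated time of 10 min; on this read-out higher numbers stand for weaker inhibition and lower numbers for stronger inhibition:

Compound 1, `COc1ccc(/C=C/C(=O)c2ccc[nH]2)cc1Br`, gives a limit of the assay, > 20000 nM, and no number.
Compound 2, `COc1cccc(/C=C/C(=O)c2ccc[nH]2)c1`, gives 6200 nM.
Compound 3, `COc1cccc(/C=C/C(=O)c2ccc[nH]2)c1OC`, gives 5200 nM.

Compound 3 holds the lowest of the two numbers shown, and its nearest neighbour is compound 2, separated by a 1.2-fold lower number from compound 2 to compound 3 (0.08 log units; within the scatter), a gap that lies within the scatter. For the measured compounds named here, the only other value is the limit for compound 1, (the limit of > 20000 nM in this assay, at which 1 of the 3 values shown sits).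

Compound 4, `COc1ccccc1/C=C/C(=O)c1ccc[nH]1`, has not yet been measured. It differs from compound 3 in one place: hydrogen in place of methoxy on an aromatic carbon. Going by the values given here, the single measured step that bears on this change is the one from compound 2 to compound 3, a 1.2-fold lower number from compound 2 to compound 3 (0.08 log units; within the scatter), which put a methoxy onto an aromatic carbon and shifted the number by an amount within the scatter. The step to compound 4 takes a methoxy off again, so no movement beyond the scatter is expected in this assay, in either direction; the expected step from compound 3 to compound 4 is a 1.2-fold higher number from compound 3 to compound 4 (0.06 log units; within the scatter). Compound 4 is therefore estimated at 6000 nM, with a range from 3000 nM to 12000 nM.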

Compound 4, half-maximal inhibitory concentration: 900 nM
Beside the measured number, compound 4's estimate is 6.7-fold (0.82 log units) above it; measured number outside the range, below it.
By their numbers in this assay, from the lowest: compound 4; then compounds 3 and 2 (each within the scatter of the next). At a limit, above all of these: compound 1.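

In this assay, a 5.8-fold lower number from compound 3 to compound 4 (0.76 log units; beyond the scatter) shows that this position is not neutral: hydrogen in place of methoxy on this aromatic carbon, ortho to a methoxy group and meta to a group of 9 heavy atoms, gives stronger inhibition. The earlier 1.2-fold lower number from compound 2 to compound 3 (0.08 log units; within the scatter) concerned a methoxy on a different carbon of the ring, so the two steps together show that the same group can matter on one carbon and not on another. Nothing shown here accounts for this difference between the two carbons.

On these data alone, whether a hydroxyl, an amine or a longer ether chain on this carbon would behave like the methoxy or like the hydrogen remains open. So does whether the same exchange made on compound 2 would give a step of similar size.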